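This account rests on a few compounds, and the source may have more. Where it says the series, first, only, none or still open, it means among the compounds named here.

In a functional assay on MCF7 cells (Homo sapiens) for antiproliferative activity, read by MTT assay, with a stated time of 72 h (on this read-out lower numbers stand for stronger inhibition and higher numbers for weaker inhibition), compound 1 `COc1cc(-n2ncnc2-c2ccc(C)cc2)cc(OC)c1OC` gives 540 nM. Compound 3 `CCOc1ccc(-c2ncnn2-c2cc(OC)c(OC)c(OC)c2)cc1Cl` gives 17 nM, which leaves compound 1 with the higher of the two exact numbers. Compound 2 `COc1cc(-c2ncnn2-c2ccc(Cl)cc2Cl)cc(OC)c1OC` gives no exact number, only a limit of > 10000 nM. Compound 4 `COc1cc(-n2ncnc2-c2ccccc2)cc(OC)c1OC` differs from compound 1 in a single place: hydrogen in place of methyl on an aromatic carbon. This puts hydrogen in place of methyl on an aromatic carbon, para to a large group, so 4-methylphenyl becomes phenyl. For the measured compounds named here, no measured pair shows this change alone, so the forecast is a judgement with a wide range. In this assay a modest move towards weaker inhibition is expected, with an estimated step of a 2.2-fold higher number from compound 1 to compound 4 (0.35 log units; beyond the scatter). The expected value for compound 4 is 1200 nM, within a range of 250 nM to 6000 nM.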

Compound 4, half-maximal inhibitory concentration: > 10000 nM
Compound 4 was reported as a limit (the forecaster's own chance of this, stated with the estimate: 10%); middle value at least 8.3-fold (0.92 log units) away from the limit.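

In this assay, this position now has a pair that isolates it, and the single methyl of the 4-methylphenyl group proves to matter: changing it to phenyl gives an at least 18-fold higher number from compound 1 to compound 4 (1.26 log units; beyond the scatter). Compound 4 gives only a limit of the assay, so this step has a lower bound but no known upper end: the limit of > 10000 nM in this assay, at which 2 of the 4 values shown sit.

From the compounds shown here alone, whether an isopropyl group or an amine in the same place would keep the activity of compound 1 stays open. So does whether any group other than methyl can support activity here.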